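The source may hold more compounds than are shown below. What is called first, only, known or untested is meant among the compounds shown, and "the series" means these compounds.

In an assay for inhibition of Indoleamine 2,3-dioxygenase 1 (Homo sapiens), with stated times of 10 min and 60 min, tested at 100 uM (on this read-out higher numbers stand for a stronger effect at the one concentration tested and lower numbers for a weaker effect), compound 1 `O=[N+]([O-])c1cc(Cl)ccc1CNc1cc(C(F)(F)F)cc2[nH]ncc12` gives 77%. In this assay compound 2 `N#Cc1cc(NCc2ccccc2[N+](=O)[O-])c2cn[nH]c2c1` gives 17%. Compound 3 `FC(F)(F)c1cccc(CNc2cc(C(F)(F)F)cc3[nH]ncc23)c1` gives 49% in this assay, which is the second highest of the three numbers: the nearest of the others is compound 1, whose number is higher by more than the usual scatter, and the furthest is compound 2, whose number is lower by more than the usual scatter. No two of these three compounds differ from each other in only one place, so none of the gaps between them can be traced to a single change in structure.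

Compound 4 `OC1CCCC(Nc2cccc(CNc3cc(C(F)(F)F)cc4[nH]ncc34)c2)C1` has not yet been measured in this assay. It differs from compound 3 in one place: (3-hydroxycyclohexyl)amino in place of trifluoromethyl on an aromatic carbon

Among the measured compounds shown here, no measured pair shows what such a change does to the read-out of this assay, so the step from compound 3 to compound 4 can only be guessed. Because compound 3 sits at 49%, the estimate for compound 4 starts from there, and the change is expected to move the number only a little, if at all beyond the scatter, as a number 7 percentage points lower from compound 3 to compound 4 (within the scatter). On that basis compound 4 is expected to give 42% in this assay, somewhere between 10% and 75%.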

Compound 4, a percentage reported as inhibition, at one concentration (the size of the read-out at that concentration, not a potency): 2%
For compound 4 the middle estimate is 40 percentage points above the measured one, and the stated range ends above it.
By their numbers in this assay, from the lowest: compound 4; then compound 2; then compound 3; then compound 1.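

In this assay, among the compounds shown here, the pair compound 3 and compound 4 is the first that differs in only one place, and it gives a number 47 percentage points lower from compound 3 to compound 4 (beyond the scatter). This shows that the read-out depends strongly on what sits at this place, on an aromatic carbon of a six-membered aromatic ring of carbon only, meta to a large group: trifluoromethyl, with no hydrogen-bond donors or acceptors, supports a clear effect, whereas (3-hydroxycyclohexyl)amino, with more heavy atoms, its own non-aromatic ring and both donors and acceptors, leaves very little. Nothing measured here identifies which feature of the incoming group accounts for this drop.

With only this one exchange at the position, the compounds shown leave open whether the loss comes from the cyclohexyl ring, its hydroxyl or the linking nitrogen, which a plain amino group, a cyclohexyl group or a simple hydroxyl would help to separate. They also leave open how other groups, such as a methyl, a chlorine or a carboxylic acid, would behave at this position, and whether the same exchange would have a similar effect in the other compounds.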